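This account rests on a few compounds, and the source may have more. Where it says the series, first, only, none or still open, it means among the compounds named here.

In an ADME assay on Caco-2 cells (Homo sapiens) for permeability, in the apical to basolateral direction (a higher number here means that the compound crosses the layer faster, a lower number that the compound crosses the layer more slowly), compound 1 `Cn1nc2c(=O)n(CC3(O)CCN(Cc4ccc(-c5ccco5)cc4Cl)CC3)cnc2c1-c1ccc(C2(N)CC2)cc1` gives 1.99 10^-6 cm/s and compound 2 `CNCc1ccc(-c2c3ncn(CC4(O)CCN(Cc5ccc(-c6ccco6)cc5Cl)CC4)c(=O)c3nn2C)cc1` gives 1.06 10^-6 cm/s (the two numbers lie within the scatter of each other, so compound 2 stands level with compound 1). Compound 3 `Cn1nc2c(=O)n(CC3(O)CCN(Cc4ccc(-c5ccco5)cc4Cl)CC3)cnc2c1-c1ccc(CNS(C)(=O)=O)cc1` differs from compound 2 in one place, with methylsulfonyl in place of methyl on an amine nitrogen so that (methylamino)methyl becomes (methanesulfonamido)methyl. Among the compounds with values here, the only measured step is a 1.9-fold lower number from compound 1 to compound 2 (0.27 log units; within the scatter) and it concerns a different change, (methylamino)methyl in place of 1-aminocyclopropyl on an aromatic carbon. Within the data shown here, no measured compound carries a methylsulfonyl group, so that small step offers only weak guidance and no direction. The expected move is a 1.2-fold higher number from compound 2 to compound 3 (0.09 log units; within the scatter) and no step beyond the scatter is foreseen. The estimate for compound 3 is 1.3 10^-6 cm/s and the expected range runs from 0.5 10^-6 cm/s as its lower end to 3.5 10^-6 cm/s as its upper end.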

Compound 3, apparent permeability: 50 10^-6 cm/s
The estimate for compound 3 lay 38-fold (1.59 log units) below the measured number; measured number above the stated range.
By their numbers in this assay, from the lowest: compounds 2 and 1 (each within the scatter of the next); then compound 3.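

In this assay the amine nitrogen of the (methylamino)methyl group proves to be a place where one change matters greatly: methylsulfonyl in place of methyl gives a 47-fold higher number from compound 2 to compound 3 (1.67 log units; beyond the scatter) and so goes far beyond the earlier step, which stayed within the scatter. Replacing 1-aminocyclopropyl with (methanesulfonamido)methyl gives a jump of similar scale, a 25-fold higher number from compound 1 to compound 3 (1.40 log units; beyond the scatter), so compound 3 stands well clear of both amine-bearing compounds. Nothing available explains why this change has so large an effect.

On these data alone, whether the jump belongs to methylsulfonyl itself or would also come with another group on that nitrogen, such as acetyl, remains open. It is also unknown whether a longer chain on the sulfonyl, as in ethylsulfonyl, would give a similar number.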